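Cyclohexyl in place of 4-methoxyphenyl: notes on compound 3

A few compounds are considered here, and "the series" means these few. Any claim that something is new, unique, unknown or untested is made for them only; others in the source may bear on it.

In a functional assay on B16 cells (Mus musculus), read by spectrophotometry, with a stated time of 3 days (on this read-out higher numbers stand for weaker inhibition and lower numbers for stronger inhibition), compound 1 (`Cc1ccc(NC(=S)N/N=C/c2cccc3ccccc23)cc1`) gives 580 nM and compound 2 (`COc1ccc(NC(=S)N/N=C/c2cccc3ccccc23)cc1`) gives 860 nM so the two cannot be separated. Compound 2 therefore stands level with compound 1 within the scatter. Among the compounds with values here, the only measured step is a 1.5-fold higher number from compound 1 to compound 2 (0.17 log units; within the scatter) for methoxy in place of methyl on an aromatic carbon. Compound 3 (`S=C(N/N=C/c1cccc2ccccc12)NC1CCCCC1`) carries cyclohexyl in place of 4-methoxyphenyl on an amide-type nitrogen and so loses the aromatic ring of that substituent. Within the data shown here, no measured step covers such an exchange, which leaves the direction open and calls for a wide range. The expected change is a 1.2-fold higher number from compound 2 to compound 3 (0.07 log units; within the scatter) in this assay and this estimate lies within the scatter. Compound 3 is estimated at 1000 nM with an expected range from 300 nM to 3500 nM in this assay once measured.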

Compound 3, half-maximal inhibitory concentration: 290 nM
Beside the measured number, compound 3's estimate is 3.4-fold (0.54 log units) above it; measured number below the stated range.
By their numbers in this assay, from the lowest: compounds 3, 1 and 2 (each within the scatter of the next, the first and the last beyond it).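

In this assay the substituent on the amide-type nitrogen need not be aromatic: cyclohexyl in place of 4-methoxyphenyl gives a 3.0-fold lower number from compound 2 to compound 3 (0.47 log units; beyond the scatter), the only step among these compounds that lies beyond the scatter. Cyclohexyl in place of 4-methylphenyl gives a 2.0-fold lower number from compound 1 to compound 3 (0.30 log units; within the scatter), which lies within the scatter, so the advantage holds against the 4-methoxyphenyl group only and cyclohexyl cannot be separated from 4-methylphenyl. Nothing available accounts for the difference between these rings at this nitrogen.

Whether a ring is needed here at all stays open: the compounds shown carry only six-membered rings on this nitrogen, and an open chain such as n-hexyl, a cyclopentyl ring or a chain ending in an amine would test that. Equally open, going by these compounds, is whether cyclohexyl behaves the same way on any other core, as all three compounds share one.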